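Changing the amine on a shared core: pyrrolidine to piperidine

A few compounds are considered here, and "the series" means these few. Any claim that something is new, unique, unknown or untested is made for them only; others in the source may bear on it.

Measured in an ADME assay on L6 cells (Rattus norvegicus) for cytotoxicity; a lower number here means a stronger inhibitor, a higher number a weaker inhibitor:
- compound 1 `CN(C)C12CC(O)C(C(c3ccccc3)C1)C(c1ccccc1)C2`: 133000 nM
- compound 2 `OC1CC2(N3CCCC3)CC(c3ccccc3)C1C(c1ccccc1)C2`: 26800 nM

Only these two compounds have been measured, and compound 2 holds the lower number at 26800 nM, while compound 1 stands at 133000 nM. The next compound in the account is compound 3 `OC1CC2(N3CCCCC3)CC(c3ccccc3)C1C(c1ccccc1)C2`, which keeps the core of compound 2 and differs on a saturated ring carbon: piperidin-1-yl in place of pyrrolidin-1-yl on a saturated ring carbon. Among the compounds with values here, one measured step bears on this change, since it concerns the same place. Putting pyrrolidin-1-yl in place of dimethylamino gave a 5.0-fold lower number from compound 1 to compound 2 (0.70 log units; beyond the scatter), a modest step beyond the scatter. Within the data shown here, no measured compound yet carries piperidin-1-yl, so that single step offers only weak guidance on direction. Replacing one ring with another is expected to matter less than the earlier replacement, with at most a slight further drift towards a lower number in this assay. The expected move is a 1.3-fold lower number from compound 2 to compound 3 (0.13 log units; within the scatter), which is probably not beyond the scatter. In this assay the estimate for compound 3 is 20000 nM, with an expected range from 7000 nM to 60000 nM.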

Compound 3, half-maximal inhibitory concentration: 37300 nM
Estimate against measurement, compound 3: 1.9-fold (0.27 log units) below; measured number inside the range.
By their numbers in this assay, from the lowest: compounds 2 and 3 (each within the scatter of the next); then compound 1.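

In this assay, the exchange of pyrrolidin-1-yl for piperidin-1-yl on this saturated ring carbon comes to a 1.4-fold higher number from compound 2 to compound 3 (0.14 log units; within the scatter) and so does not separate the two ring amines. The lower number relative to dimethylamino is therefore not confined to pyrrolidin-1-yl: alongside a 5.0-fold lower number from compound 1 to compound 2 (0.70 log units; beyond the scatter) there now stands a 3.6-fold lower number from compound 1 to compound 3 (0.55 log units; beyond the scatter) in the same direction, and among these three compounds neither ring amine goes against that pattern. No evidence is available to explain the difference between the ring amines and dimethylamino.

The compounds shown leave open whether a larger ring such as azepan-1-yl, a ring with a second hetero atom such as morpholin-4-yl, or an unsubstituted amine on this carbon would stay close to the numbers of compound 2 and compound 3 or move back towards that of compound 1. Going by these compounds, all three compounds also carry the same hydroxy and phenyl groups, so it remains open whether the same pattern would hold with a methoxy group or a carbonyl in place of the hydroxy group.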